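The source may report more compounds than this note shows. Statements on the series, on what has been measured and on what is new or still open speak of the compounds shown alone.

In an ADME assay on Vero cells (Chlorocebus sabaeus) for cytotoxicity, read by MTT assay, with a stated time of 72 h (a lower number here means that less compound is tolerated, a higher number that more compound is tolerated), compound 3 (`COc1c(N2CCN(CC/C(C)=N/O)C(C)C2)c(F)cc2c(=O)c(C(=O)O)cn(C3CC3)c12`) stands lowest of the three numbers at 44.2 ug/mL against compound 2 (`COc1c(N2CCN(C/C(C)=N/NC(=O)c3ccncc3)C(C)C2)c(F)cc2c(=O)c(C(=O)O)cn(C3CC3)c12`) at 250 ug/mL and compound 1 (`COc1c(N2CCN(C/C(C)=N/NC(C)=O)C(C)C2)c(F)cc2c(=O)c(C(=O)O)cn(C3CC3)c12`) at 707 ug/mL in the same read-out. Compound 4 (`CCO/N=C(\C)CCN1CCN(c2c(F)cc3c(=O)c(C(=O)O)cn(C4CC4)c3c2OC)CC1C`) differs from compound 3 by ethyl in place of hydrogen on an oxygen as hydroxy goes to ethoxy. Within the data shown here, no measured step makes this change. The nearest guide is a 2.8-fold lower number from compound 1 to compound 2 (0.45 log units; beyond the scatter) with pyridin-4-yl in place of methyl on a carbonyl carbon. The steps of a 16-fold lower number from compound 1 to compound 3 (1.20 log units; beyond the scatter) and a 5.7-fold lower number from compound 2 to compound 3 (0.75 log units; beyond the scatter) exchange a whole group on a saturated chain carbon and bear on it less directly. No step beyond the scatter is therefore expected, only a slight lean to a lower number: the estimated step is a 1.3-fold lower number from compound 3 to compound 4 (0.10 log units; within the scatter) for now. The expected value for compound 4 is 35 ug/mL with a range from 12 ug/mL to 100 ug/mL as estimated.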

Compound 4, half-maximal cytotoxic concentration: 88.4 ug/mL
The estimate for compound 4 lay 2.5-fold (0.40 log units) below the measured number; measured number inside the range.
By their numbers in this assay, from the lowest: compounds 3 and 4 (each within the scatter of the next); then compound 2; then compound 1.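

In this assay, among these compounds, ethyl in place of hydrogen on an oxygen whose other neighbour is a double-bonded nitrogen stays within the scatter (a 2.0-fold higher number from compound 3 to compound 4 (0.30 log units; within the scatter)), the first reading of a change at this oxygen. With ethoxy in place, the exchanges of a whole group on the saturated chain carbon remain beyond the scatter (a 2.8-fold lower number from compound 2 to compound 4 (0.45 log units; beyond the scatter); an 8.0-fold lower number from compound 1 to compound 4 (0.90 log units; beyond the scatter)). Hydroxy to ethoxy therefore does not close the gap to the two hydrazone-bearing compounds, compound 1 and compound 2.

Going by these compounds, whether a longer chain or a carboxylic acid on this oxygen would also stay within the scatter of compound 3 remains open. No supporting evidence accompanies these numbers to explain them.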